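Replacing 4-(trifluoromethoxy)phenyl with 3-chlorophenyl in the hydroxy series

A few compounds are considered here, and "the series" means these few. Any claim that something is new, unique, unknown or untested is made for them only; others in the source may bear on it.

In a functional assay on KB cells (Homo sapiens) for inhibition, read by sulforhodamine B assay (on this read-out higher numbers stand for weaker inhibition of growth and lower numbers for stronger inhibition of growth), compound 3 `Oc1cccc2[nH]c(-c3ccc(-c4ccc(-c5ccc(OC(F)(F)F)cc5)cc4)cc3)nc12` gives 3310 nM. That lies within the scatter of compound 1 `Cc1ccc2[nH]c(-c3ccc(-c4ccc(-c5cccc(Cl)c5)cc4)cc3)nc2c1` at 2260 nM, while compound 2 `FC(F)(F)Oc1ccc(-c2ccc(-c3ccc(-c4nc5ccccc5[nH]4)cc3)cc2)cc1` gives 39100 nM. Within the data shown here, the only measured step, a 12-fold lower number from compound 2 to compound 3 (1.07 log units; beyond the scatter), is hydroxy in place of hydrogen on an aromatic carbon, and it leaves the exchanged group untouched. Compound 4 `Oc1cccc2[nH]c(-c3ccc(-c4ccc(-c5cccc(Cl)c5)cc4)cc3)nc12` keeps that hydroxy and carries 3-chlorophenyl in place of 4-(trifluoromethoxy)phenyl on an aromatic carbon. Among the measured compounds shown here, no measured step isolates this exchange. The nearest evidence is that compound 1, with 3-chlorophenyl on a different core, gives 2260 nM. No step beyond the scatter is therefore expected in this assay, and the estimated change is a 1.7-fold lower number from compound 3 to compound 4 (0.22 log units; within the scatter). Compound 4 is expected at 2000 nM, within an estimated range of 600 nM to 6500 nM.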

Compound 4, concentration for 50% growth inhibition: 2280 nM
Beside the measured number, compound 4's estimate is 1.1-fold (0.06 log units) below it; the range from low to high includes it.
By their numbers in this assay, from the lowest: compounds 1, 4 and 3 (each within the scatter of the next); then compound 2.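

In this assay, the exchange of 4-(trifluoromethoxy)phenyl for 3-chlorophenyl now has its own measured step on the hydroxy core (a 1.5-fold lower number from compound 3 to compound 4 (0.16 log units; within the scatter)). Compound 3 and compound 4 therefore sit within the scatter of each other, so this position accepts either group without a step beyond the scatter. No measured property available here accounts for this result. Open, going by these compounds, is whether an amine or a carboxylic acid at this place would stay in that range. Also open, on these data alone, is whether the two groups also match without the hydroxy.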